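The compounds below may be only part of what the source reports. "The series", "measured", "known", "first", "only" and "open" are said of these compounds alone.

Working notes on the series. In an assay on cells for inhibition of S-adenosylmethionine decarboxylase proenzyme (Homo sapiens), read by mass spectrometry, at pH 7.2 (a higher number here means a weaker inhibitor, a lower number a stronger inhibitor), compound 1 `Cc1cc(Nc2cccc(Cl)c2)nc(N)n1` gives > 180000 nM, which is a limit of the assay rather than a measured number. Compound 2 `Cc1cc(Nc2cccc(F)c2)nc(N)n1`, in this assay, likewise gives > 180000 nM, again a limit. The change from compound 1 to compound 2 is fluoro in place of chloro on an aromatic carbon; the step that the two limits leave unreadable from compound 1 to compound 2 cannot be sized, since the limit of > 180000 nM in this assay, at which 2 of the 2 values shown sit, covers both values shown.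

Compound 3 `Cc1cc(Nc2cc(Cl)cc(-c3ccc(O)cc3)c2)nc(N)n1` remains to be measured in this assay. Against compound 1 the change is 4-hydroxyphenyl in place of hydrogen on an aromatic carbon. Among the compounds with values here, no measured step touches this kind of change, and the only measured step, from compound 1 to compound 2, is itself unreadable. Where compound 1 stands is known only as a limit, so no direction can be read for the step to compound 3 from the numbers in hand.

For compound 3 the value in this assay is therefore expected near 120000 nM, within roughly 20000 nM to 400000 nM, with a fair chance that only a limit is reported; the step from compound 1 to compound 3 is thus estimated as an at least 1.5-fold lower number from compound 1 to compound 3 (0.17 log units; that floor lies within the scatter).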

Compound 3, half-maximal inhibitory concentration: > 180000 nM
Compound 3: no number, only a limit (the forecaster's own chance of this, stated with the estimate: 55%); at least 1.5-fold (0.17 log units) between middle value and limit.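

The step from compound 1 to compound 3 cannot be read in this assay, and the series so far yields only limits: the limit of > 180000 nM in this assay, at which 3 of the 3 values shown sit.

The compounds shown leave open whether fluoro, chloro or 4-hydroxyphenyl on the shared core changes the result in this assay at all, and how far each compound lies beyond the limit.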